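This account rests on a few compounds, and the source may have more. Where it says the series, first, only, none or still open, it means among the compounds named here.

Measured compounds: compound 1 `O=C(Nc1cccc(-n2cc(-c3ccncc3)c(-c3ccc(Cl)c(O)c3)n2)c1)Nc1cccc(C(F)(F)F)c1` gives > 32500 nM in a functional assay on BT-549 cells (Homo sapiens) for inhibition, read by sulforhodamine B assay, with a stated time of 48 h (on this read-out higher numbers stand for lower toxicity in this test and lower numbers for higher toxicity in this test), a limit of the assay. Compound 2 `COc1cc(-c2nn(-c3cccc(NC(=O)Nc4cc(C(F)(F)F)cc(C(F)(F)F)c4)c3)cc2-c2ccncc2)ccc1Cl` gives 29600 nM. Compound 3 `COc1cc(-c2nn(-c3cccc(NC(=O)Nc4cccc(C(F)(F)F)c4)c3)cc2-c2ccncc2)ccc1Cl` gives 50000 nM.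

Among the two numbers shown, compound 2 stands lowest; its nearest neighbour is compound 3, at a 1.7-fold higher number from compound 2 to compound 3 (0.23 log units; within the scatter), which is within the scatter. Compound 4 `O=C(Nc1cccc(-n2cc(-c3ccncc3)c(-c3ccc(Cl)c(O)c3)n2)c1)Nc1cc(C(F)(F)F)cc(C(F)(F)F)c1` differs from compound 2 by hydrogen in place of methyl on an oxygen on an aromatic ring. The same change, read the other way, has been measured once: a step that the limit leaves unreadable from compound 1 to compound 3, and that step is unreadable in size because of the limit of > 32500 nM in this assay, at which 1 of the 3 values shown sits. Nothing here therefore shows a step beyond the scatter in either direction. Compound 4 is expected at 35000 nM in this assay, between 15000 nM and 80000 nM, the estimated step of a 1.2-fold higher number from compound 2 to compound 4 (0.07 log units; within the scatter) lying within the scatter.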

Compound 4, concentration lethal to 50% of the cells: 4110 nM
The estimate for compound 4 lay 8.5-fold (0.93 log units) above the measured number; the measured number lies below the stated range.
By their numbers in this assay, from the lowest: compound 4; then compounds 2 and 3 (each within the scatter of the next).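

In this assay, methoxy to hydroxy on the 4-chloro-3-methoxyphenyl group now gives a readable step, and it lies beyond the scatter: a 7.2-fold lower number from compound 2 to compound 4 (0.86 log units; beyond the scatter). On the hydroxy compounds, trifluoromethyl in place of hydrogen on an aromatic carbon gives an at least 7.9-fold lower number from compound 1 to compound 4 (0.89 log units; beyond the scatter), a size bounded by the assay limit of compound 1. The size of this trifluoromethyl change thus differs with the group on the oxygen: the same change on two cores in this assay, a 1.7-fold higher number (0.23 log units; within the scatter) from compound 2 to compound 3 and an at least 7.9-fold higher number (0.89 log units; beyond the scatter) from compound 4 to compound 1, at least 4.6-fold (0.67 log units) apart, beyond the scatter of two such steps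

The compounds shown leave open how an amine or an ethoxy group in place of the methoxy would read. The hydroxy step with a single trifluoromethyl, from compound 3 to compound 1, cannot be read.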